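Swapping the aryl group on an imidazolinone glucagon receptor series

The compounds below may be only part of what the source reports. "The series", "measured", "known", "first", "only" and "open" are said of these compounds alone.

Among the measured compounds shown here, compound 1 `C[C@H](c1ccc(C(=O)NCCC(=O)O)cc1)N1C(=O)C(c2cccc(OC(F)(F)F)c2)=N[C@]12CC[C@@H](C(C)(C)C)CC2` gives 1500 nM in an assay on membranes from liver for displacement of a labelled ligand from Glucagon receptor (Mus musculus), read by scintillation counting, with a stated time of 60 min (on this read-out higher numbers stand for weaker inhibition and lower numbers for stronger inhibition), the highest of the two numbers known; compound 2 `CC1(CC[C@H](c2ccc(C(=O)NCc3nn[nH]n3)cc2)N2C(=O)C(c3cc(Cl)cc(Cl)c3)=N[C@]23CC[C@@H](C(C)(C)C)CC3)CC1` gives 110 nM, a lower number beyond the scatter, but it differs in several places. Compound 3 `C[C@H](c1ccc(C(=O)NCCC(=O)O)cc1)N1C(=O)C(c2ccccc2F)=N[C@]12CC[C@@H](C(C)(C)C)CC2` carries the change (2-fluorophenyl in place of 3-(trifluoromethoxy)phenyl on a carbon with a double bond to nitrogen). For the measured compounds named here, no measured pair isolates this change, so the direction rests on no precedent; a step of modest size, within or only just beyond the scatter, is expected, giving a 1.3-fold higher number from compound 1 to compound 3 (0.12 log units; within the scatter). For compound 3 the estimate is 2000 nM, with a range from 500 nM to 8000 nM.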

Compound 3, half-maximal inhibitory concentration: > 10000 nM
Compound 3 gave a limit, no number (the forecaster's own chance of this, stated with the estimate: 10%); middle value at least 5.0-fold (0.69 log units) away from the limit.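

In this assay compound 3 reads > 10000 nM, which is a limit of the assay and not a number. Even so, this pair isolates the group on the carbon with a double bond to nitrogen: 2-fluorophenyl in place of 3-(trifluoromethoxy)phenyl gives an at least 6.6-fold higher number from compound 1 to compound 3 (0.82 log units; beyond the scatter). This position therefore does not treat these two aryl groups alike.

The compounds shown leave open whether the fluorine or the missing trifluoromethoxy group accounts for this step. Going by these compounds, how a plain phenyl or a 3-methoxyphenyl group would read on the core of compound 1 remains unknown.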